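A few compounds are considered here, and "the series" means these few. Any claim that something is new, unique, unknown or untested is made for them only; others in the source may bear on it.

Three compounds share one core and differ only in the group attached to the amide-type nitrogen. Compound 1 `O=C(COc1ccc2cc(/C=C3/SC(=O)NC3=O)ccc2c1)Nc1ccccc1` carries a plain phenyl there, and in an assay on isolated protein for inhibition of histone deacetylase 4 (Homo sapiens), with a stated time of 1 h (a lower number here means a stronger inhibitor, a higher number a weaker inhibitor), compound 1 gives 2100 nM. Compound 2 `Cc1cc(Br)ccc1NC(=O)COc1ccc2cc(/C=C3/SC(=O)NC3=O)ccc2c1` carries a 4-bromo-2-methylphenyl, and in this assay compound 2 gives 550 nM. Compound 3 `O=C(COc1ccc2cc(/C=C3/SC(=O)NC3=O)ccc2c1)Nc1ccc([N+](=O)[O-])cc1` carries a 4-nitrophenyl, and in this assay compound 3 gives 1700 nM. Among these three numbers compound 3 stands second highest: the step of a 1.2-fold lower number from compound 1 to compound 3 (0.09 log units; within the scatter) lies within the scatter, while the step of a 3.1-fold higher number from compound 2 to compound 3 (0.49 log units; beyond the scatter) lies beyond it.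

Compound 4 `O=C(COc1ccc2cc(/C=C3/SC(=O)NC3=O)ccc2c1)Nc1ccc(F)cc1` differs from compound 3 in one place: fluoro in place of nitro on an aromatic carbon. Going by the values given here, two measured steps bear on this change. The step of a 1.2-fold lower number from compound 1 to compound 3 (0.09 log units; within the scatter) shows that adding a nitro at this position changed little, so removing it should change little as well. The step of a 3.8-fold lower number from compound 1 to compound 2 (0.58 log units; beyond the scatter) shows that a ring bearing a halogen together with a methyl did lower the number, though compound 4 carries a fluoro alone. Taken together, the expectation is a step of a 1.1-fold lower number from compound 3 to compound 4 (0.05 log units; within the scatter) that stays within the scatter. Compound 4 is therefore estimated at 1500 nM, with a range from 600 nM to 3500 nM.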

Compound 4, half-maximal inhibitory concentration: 1600 nM
Compound 4: middle estimate off by 1.1-fold (0.03 log units), on the low side; low and high end bracket the measured number.
By their numbers in this assay, from the lowest: compound 2; then compounds 4, 3 and 1 (each within the scatter of the next).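

Fluoro joins nitro and plain hydrogen as a third substituent on this aromatic carbon that leaves the number essentially unmoved in this assay: the result is a 1.1-fold lower number from compound 3 to compound 4 (0.03 log units; within the scatter) and, measured against the unsubstituted ring, a 1.3-fold lower number from compound 1 to compound 4 (0.12 log units; within the scatter), both small enough that these three rings cannot be told apart here. The swap of a three-atom nitro for a single fluorine atom thus adds a second, quite different group to the evidence that a lone substituent at this place, at least among these, makes no clear difference, and compound 2 remains the only one that stands apart, with a 2.9-fold higher number from compound 2 to compound 4 (0.46 log units; beyond the scatter) going beyond the scatter. Nothing available here gives a reason for these results.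

The compounds shown do not separate the bromo from the methyl, so it stays open whether either group alone on the ring would be enough to lower the number or whether the two are needed together. Also open, from the compounds shown here alone, is how the number would respond to an amine or a carboxylic acid on this same aromatic carbon.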